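Thioamide series: allyl to (2-hydroxyethoxy)methyl on the ring nitrogen

The source may hold more compounds than are shown below. What is called first, only, known or untested is meant among the compounds shown, and "the series" means these compounds.

Among the compounds with values here, compound 1 `C=CCn1cc(C(N)=S)c2c(N)ncnc21` carries a thioamide on the shared core and gives 19000 nM in a functional assay on KB cells (Homo sapiens) for cytotoxicity (a higher number here means a weaker inhibitor, a lower number a stronger inhibitor), the lowest of the two numbers measured so far. Compound 2 `C=CCn1cc(C(N)=O)c2c(N)ncnc21`, the amide, gives 100000 nM; the step of a 5.3-fold higher number from compound 1 to compound 2 (0.72 log units; beyond the scatter) lies beyond the scatter and concerns the thioamide alone.

Compound 3 `NC(=S)c1cn(COCCO)c2ncnc(N)c12` keeps the thioamide and differs from compound 1 only at the chain on the ring nitrogen: 2-hydroxyethoxy in place of vinyl on a saturated chain carbon bound to an aromatic nitrogen. Within the data shown here, no measured step touches that chain, so the only step in hand, a 5.3-fold higher number from compound 1 to compound 2 (0.72 log units; beyond the scatter), gives no direct guidance for this change, and the expectation rests on the unchanged thioamide and core.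

The estimate for compound 3 is therefore a number close to that of compound 1, a 1.6-fold higher number from compound 1 to compound 3 (0.20 log units; within the scatter), with a wide band: 30000 nM, expected between 6000 nM and 150000 nM in this assay.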

Compound 3, half-maximal inhibitory concentration: 115000 nM
Compound 3: middle estimate off by 3.8-fold (0.58 log units), on the low side, within the range that was stated.
By their numbers in this assay, from the lowest: compound 1; then compounds 2 and 3 (each within the scatter of the next).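

At this place, on a saturated chain carbon bound to an aromatic nitrogen, the change is not silent: 2-hydroxyethoxy in place of vinyl gives a 6.1-fold higher number from compound 1 to compound 3 (0.78 log units; beyond the scatter) in this assay with the thioamide and the shared core held fixed. The chain therefore counts here as well as the thioamide, and compound 1, with its allyl chain, remains the lowest number of the three compounds. Nothing measured explains this step.

With only two chains shown on the thioamide, it stays open whether the step follows the hydroxyl, the ether oxygen or the length of the chain. A plain propyl chain, a longer alkyl chain or a (2-aminoethoxy)methyl chain at this place would help to separate these readings.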